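Swapping methoxy for fluoro at a shared limit

The source may report more compounds than this note shows. Statements on the series, on what has been measured and on what is new or still open speak of the compounds shown alone.

Compound 1, `CCCCCCCCCOc1ccc2nncn2n1`: in a functional assay on the whole organism with Mus musculus as the target (a lower number here means that less compound is needed, a higher number that more compound is needed for the effect), compound 1 gives > 100 mg/kg, which is a limit, not a number.
Compound 2, `Cc1ccc(Oc2ccc3nncn3n2)cc1`: in this assay compound 2 gives > 100 mg/kg, also a limit.
Compound 3, `COc1ccc(Oc2ccc3nncn3n2)cc1`: in this assay compound 3 gives > 100 mg/kg, again a limit.

Compound 3 therefore stands only at a limit, with no number beneath it. Going by the values given here, the single measured step between two compounds that differ in one place is a step that the two limits leave unreadable from compound 2 to compound 3; both its ends are limits and no size can be read from it. Compound 4, `Fc1ccc(Oc2ccc3nncn3n2)cc1`, differs from compound 3 by fluoro in place of methoxy on an aromatic carbon. Among the compounds with values here, no measured step bears on this change in a readable way; the only pointer is the limit of > 100 mg/kg in this assay, at which 3 of the 3 values shown sit, so no step beyond the scatter is expected, and the expected step is a step that the limit leaves unreadable from compound 3 to compound 4. Compound 4 is accordingly estimated at 150 mg/kg, within 40 mg/kg to 600 mg/kg, most probably again a limit.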

Compound 4, dose for half-maximal effect: 38 mg/kg
Beside the measured number, compound 4's estimate is 3.9-fold (0.60 log units) above it; the whole stated range lies above it.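

In this assay, the group on this aromatic carbon turns out to matter: fluoro in place of methoxy gives an at least 2.6-fold lower number from compound 3 to compound 4 (0.42 log units; beyond the scatter), and fluoro in place of methyl gives an at least 2.6-fold lower number from compound 2 to compound 4 (0.42 log units; beyond the scatter). Both steps are minimum sizes, since one end of each is a limit and not a number. Compound 4 is the first compound here to give a number, while the others remain at a limit: the limit of > 100 mg/kg in this assay, at which 3 of the 4 values shown sit.

The compounds shown leave open how large these steps really are and why fluoro differs from methyl and methoxy. They also leave open whether chloro, a nitrile or an amine at this place would give a lower number than compound 4.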